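The source may hold more compounds than are shown below. What is called first, only, known or untested is meant among the compounds shown, and "the series" means these compounds.

Values in a functional assay on HepG2 cells (Homo sapiens) for antiproliferative activity, read by CCK-8 assay, with a stated time of 72 h (a lower number here means a stronger inhibitor, a higher number a weaker inhibitor), so far:
Compound 1 `Nc1ccccc1NC(=O)c1ccc(COc2ccc(Cl)cc2)cc1` gives > 32000 nM (a limit)
Compound 2 `Cc1ccc(OCc2ccc(C(=O)Nc3ccccc3N)cc2)cc1` gives 6590 nM (a number)
Compound 3 `CC(C)c1ccc(OCc2ccc(C(=O)Nc3ccccc3N)cc2)cc1` gives > 32000 nM (a limit)

Compound 3 has no number, only the limit > 32000 nM in this assay. It shares this position with one other compound (the limit of > 32000 nM in this assay, at which 2 of the 3 values shown sit).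

The next compound is its isomer, compound 4 `CCCc1ccc(OCc2ccc(C(=O)Nc3ccccc3N)cc2)cc1`, with propyl in place of isopropyl on an aromatic carbon, para to a large group (propyl in place of isopropyl on an aromatic carbon). Within the data shown here, no measured step makes this exchange directly.

The nearest evidence is the change of methyl to isopropyl, an at least 4.8-fold higher number from compound 2 to compound 3 (0.68 log units; beyond the scatter), which is beyond the scatter. The change of chloro to methyl, an at least 4.8-fold lower number from compound 1 to compound 2 (0.68 log units; beyond the scatter), is also beyond the scatter and shows that this position can move the read-out. The third step, a step that the two limits leave unreadable from compound 1 to compound 3, adds nothing on size.

Compound 4 is expected to lie near its isomer, and compound 2 at 6590 nM marks the best level seen so far. A limit reading is about as likely as a number. The estimated change is an at least 1.6-fold lower number from compound 3 to compound 4 (0.20 log units; that floor lies within the scatter) in this assay and, if readable at all, is expected to point to a lower number. The estimated value for compound 4 is 20000 nM within an expected range of 7000 nM to 32000 nM in this assay.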

Compound 4, half-maximal inhibitory concentration: 4750 nM
The estimate for compound 4 lay 4.2-fold (0.62 log units) above the measured number; measured number below the stated range.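

In this assay, propyl in place of isopropyl on the aromatic carbon gives an at least 6.7-fold lower number from compound 3 to compound 4 (0.82 log units; beyond the scatter), so two groups with the same atoms, joined differently, are clearly separated at this position. Ethyl in place of hydrogen on the saturated chain carbon bound to the aromatic carbon gives a 1.4-fold lower number from compound 2 to compound 4 (0.14 log units; within the scatter), which shows that the loss seen with isopropyl does not extend to every group larger than methyl. Propyl in place of chloro gives an at least 6.7-fold lower number from compound 1 to compound 4 (0.82 log units; beyond the scatter), and the steps that start from compound 1 or compound 3 give only a floor for their size: the limit of > 32000 nM in this assay, at which 2 of the 4 values shown sit.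

The step between compound 1 and compound 3 cannot be read, and the isopropyl result alone leaves it open whether other branched groups, such as tert-butyl, behave in the same way. As far as these compounds go, it also remains open whether a longer chain such as butyl stays level with compound 2 and compound 4, and whether an amine or a carboxylic acid at the end of the propyl chain would be tolerated at this position.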